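The source may hold more compounds than are shown below. What is called first, only, known or untested is meant among the compounds shown, and "the series" means these compounds.

Compound 2 `CC(C)N(Cc1cccc(OCCCCCC(=O)O)c1)C(=O)c1ccc(-c2ccc3[nH]ccc3c2)cc1` carries a 1H-indol-5-yl group on the shared core. In an ADME assay on HepG2 cells (Homo sapiens) for cytotoxicity, read by CellTiter-Glo and resazurin assay, with a stated time of 72 h (on this read-out lower numbers stand for an effect already at smaller amounts and higher numbers for an effect only at larger amounts of compound), compound 2 gives > 26000 nM, which is a limit of the assay rather than a measured number. Compound 1 `CC(C)N(Cc1cccc(OCCCCCC(=O)O)c1)C(=O)c1ccc(-c2cccc(-c3ccccc3)c2)cc1` is its closest measured relative. In this assay compound 1 gives > 26000 nM, again a limit and not a number. The step between them, a step that the two limits leave unreadable from compound 1 to compound 2, therefore cannot be sized. Both measured values sit at the same point, (the limit of > 26000 nM in this assay, at which 2 of the 2 values shown sit). Compound 3 `CC(C)N(Cc1cccc(OCCCCCC(=O)O)c1)C(=O)c1ccc(-c2ccc3c(c2)OCCO3)cc1` is the next compound, not yet measured. It differs from compound 2 in a single place: 2,3-dihydro-1,4-benzodioxin-6-yl in place of 1H-indol-5-yl on an aromatic carbon. Within the data shown here, only the step that the two limits leave unreadable from compound 1 to compound 2 bears on this change, and it is unreadable, so nothing measured shows a shift beyond the scatter in either direction. The step that the limit leaves unreadable from compound 2 to compound 3 is an estimate only, and it is expected to stay within the scatter. The value for compound 3 in this assay is estimated at 40000 nM, with a range from 15000 nM to 120000 nM, and it is most likely that this assay will again report only a limit.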

Compound 3, half-maximal effective concentration: > 21900 nM
Compound 3 gave a limit, no number; the forecaster's own chance of this, stated with the estimate: 80%; the middle value lies beyond the limit too.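

In this assay, compound 1, compound 2 and compound 3 all give limits rather than numbers, so the steps between them cannot be read. The compounds shown leave open whether any group at this aromatic carbon of the shared core would give an effect on these cells that can be stated as a number.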